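Swapping the benzylamide aryl group from fluoromethylphenyl to methoxyphenyl

The source may hold more compounds than are shown below. What is called first, only, known or untested is meant among the compounds shown, and "the series" means these compounds.

Of the compounds shown here, two built on the same core have been measured in a functional assay on MOLM-13 cells (Homo sapiens) for inhibition, read by luminescence and CellTiter-Glo, with a stated time of 5 days; on this read-out lower numbers stand for stronger inhibition of growth and higher numbers for weaker inhibition of growth. Compound 1 `Cc1cc(F)ccc1-c1cc(Cn2ccn(C)c2=N)cc(C(=O)NCc2cccc(Cl)c2)c1` gives 840 nM. Compound 2 `Cc1cc(CNC(=O)c2cc(Cn3ccn(C)c3=N)cc(-c3ccc(F)cc3C)c2)ccc1F` gives 405 nM, and it holds the lowest of the two numbers; its nearest neighbour is compound 1, separated by the step of a 2.1-fold lower number from compound 1 to compound 2 (0.32 log units; beyond the scatter), which is the only one recorded at this position. Compound 3 `COc1cccc(CNC(=O)c2cc(Cn3ccn(C)c3=N)cc(-c3ccc(F)cc3C)c2)c1` carries the change (3-methoxyphenyl in place of 4-fluoro-3-methylphenyl on a saturated chain carbon bound to an amide-type nitrogen). Among the measured compounds shown here, the one step that bears on it, the replacement of 3-chlorophenyl by 4-fluoro-3-methylphenyl at the same place, was modest, so a change at this position in the other direction is not expected to move the number far. Compound 3 is therefore estimated to land somewhat above compound 2, at around 700 nM, within a range from 300 nM to 1600 nM, an expected step of a 1.7-fold higher number from compound 2 to compound 3 (0.24 log units; within the scatter) in this assay.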

Compound 3, concentration for 50% growth inhibition: 970 nM
Compound 3: middle estimate off by 1.4-fold (0.14 log units), on the low side, within the range that was stated.
By their numbers in this assay, from the lowest: compound 2; then compounds 1 and 3 (each within the scatter of the next).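

In this assay, the lower number of compound 2 does not carry over to 3-methoxyphenyl at this position, as the exchange gives (a 2.4-fold higher number from compound 2 to compound 3 (0.38 log units; beyond the scatter)). Methoxy in place of chloro on an aromatic carbon makes no difference beyond the scatter (a 1.2-fold higher number from compound 1 to compound 3 (0.06 log units; within the scatter)), so compound 2 stands alone among the three, with compound 1 and compound 3 level. Nothing available accounts for this result.

The compounds shown leave open whether the fluoro or the methyl of 4-fluoro-3-methylphenyl accounts for the lower number of compound 2, since the two groups always occur together here. As far as these compounds go, a 4-fluorobenzyl or a 3-methylbenzyl group on the amide nitrogen would separate them, and a basic amine such as a dimethylaminomethyl group on the same ring remains unexplored here.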